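The source may report more compounds than this note shows. Statements on the series, on what has been measured and on what is new or still open speak of the compounds shown alone.

Measured compounds and their values:
compound 1 `CCCCCCCCNc1nc(SCc2ccc(C(F)(F)F)cc2)nc2ccccc12` — 26100 nM
compound 2 `CCCCCCCCCCCCNc1nc(SCc2ccc(C(F)(F)F)cc2)nc2ccccc12` — > 50000 nM (a limit)
compound 3 `CCCCCCCCCCCCCCNc1nc(SCc2ccc(C(F)(F)F)cc2)nc2ccccc12` — > 50000 nM (a limit)

Going by the values given here, in a functional assay on MCF7 cells (Homo sapiens) for cytotoxicity, read by MTT assay, with a stated time of 72 h (on this read-out lower numbers stand for stronger inhibition and higher numbers for weaker inhibition), compound 1 gives 26100 nM, the only plain number among the three. For compound 2 and compound 3 only the limit of the assay is known, (the limit of > 50000 nM in this assay, at which 2 of the 3 values shown sit). Lengthening the chain thus gave an at least 1.9-fold higher number from compound 1 to compound 2 (0.28 log units; that floor lies within the scatter) and an at least 1.9-fold higher number from compound 1 to compound 3 (0.28 log units; that floor lies within the scatter), while a step that the two limits leave unreadable from compound 2 to compound 3.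

Compound 4 `FC(F)(F)c1ccc(CSc2nc(Nc3ccccc3)c3ccccc3n2)cc1` differs from compound 1 by phenyl in place of octyl on a nitrogen on an aromatic ring. Among the compounds with values here, none of the measured steps swaps the chain for a ring; they only lengthen the chain, and each reached a limit. The expected step is estimated as a 1.3-fold lower number from compound 1 to compound 4 (0.12 log units; within the scatter). Compound 4 is estimated at 20000 nM, within the range 5000 nM to 50000 nM.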

Compound 4, half-maximal inhibitory concentration: 44000 nM
Beside the measured number, compound 4's estimate is 2.2-fold (0.34 log units) below it, and the stated range covers the measured number.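

In this assay, putting phenyl in place of octyl on this nitrogen gives a 1.7-fold higher number from compound 1 to compound 4 (0.23 log units; within the scatter), so at this position an aromatic ring of carbon only can stand in for the chain without a change that stands out from the scatter. Compound 2 and compound 3 remain limits, which leaves compound 4 as the only other plain number to set against compound 1: the limit of > 50000 nM in this assay, at which 2 of the 4 values shown sit.

Still open, as far as these compounds go, is whether a phenyl ring carrying an amine or a carboxylic acid would read the same. A chain shorter than octyl, such as butyl, is also left open.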